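A few compounds are considered here, and "the series" means these few. Any claim that something is new, unique, unknown or untested is made for them only; others in the source may bear on it.

Working notes on the series.

Compound 3 `COc1ccc(-c2cc(=O)c3c(OC)cc(OC)cc3n2S(=O)(=O)c2cc(F)c(F)c(F)c2)cc1` sits at the edge of what a functional assay on KOPN-8 cells (Homo sapiens) for antiproliferative activity, with a stated time of 72 h (a higher number here means that more compound is needed for the effect, a lower number that less compound is needed), reports: for compound 3 the readout is only a limit, > 65500 nM, not a number (the limit of > 65500 nM in this assay, at which 1 of the 3 values shown sits). The measured step leading into it, an at least 3.7-fold higher number from compound 2 to compound 3 (0.57 log units; beyond the scatter), comes from compound 2 `COc1ccc(-c2cc(=O)c3c(OC)cc(OC)cc3n2S(=O)(=O)c2ccc([N+](=O)[O-])cc2)cc1`, which in this assay gives 17300 nM. Compound 1 `COc1ccc(-c2c(Br)c(=O)c3c(OC)cc(OC)cc3n2S(=O)(=O)c2ccc(OC)cc2)cc1`, carrying bromine on the shared core together with a 4-methoxyphenyl on the sulfonyl sulfur, gives 2580 nM in this assay.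

The step under review is 4-methoxyphenyl in place of 3,4,5-trifluorophenyl on a sulfonyl sulfur, giving compound 4 `COc1ccc(-c2cc(=O)c3c(OC)cc(OC)cc3n2S(=O)(=O)c2ccc(OC)cc2)cc1`. Of the measured steps only the exchange of the sulfonyl aryl group bears on it, and that one, an at least 3.7-fold higher number from compound 2 to compound 3 (0.57 log units; beyond the scatter), ran toward a higher number when 3,4,5-trifluorophenyl replaced 4-nitrophenyl. Reversing the direction toward a 4-methoxyphenyl, the group also present in compound 1 with its value of 2580 nM, a step toward a lower number is expected, an at least 10-fold lower number from compound 3 to compound 4 (1.03 log units; beyond the scatter), though the bromine of compound 1 is absent here and its contribution is unmeasured. Compound 4 is therefore estimated at 6000 nM in this assay, within 1500 nM to 25000 nM.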

Compound 4, half-maximal effective concentration: > 82700 nM
Compound 4: a limit, no number (the forecaster's own chance of this, stated with the estimate: 10%); middle value at least 13-fold (1.13 log units) away from the limit.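

In this assay compound 4 gives > 82700 nM, which is a limit and not a number: the limit of > 82700 nM in this assay, at which 1 of the 4 values shown sits. The step between the two limits cannot be read, but methoxy in place of nitro on an aromatic carbon gives an at least 4.7-fold higher number from compound 2 to compound 4 (0.67 log units; beyond the scatter), so 4-methoxyphenyl on the sulfonyl sulfur, like 3,4,5-trifluorophenyl, goes with a higher number than 4-nitrophenyl. Hydrogen in place of bromo on an aromatic carbon gives an at least 32-fold higher number from compound 1 to compound 4 (1.50 log units; beyond the scatter), so the lower number of compound 1 goes with the bromine on the shared core and not with the 4-methoxyphenyl alone.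

Going by these compounds, whether chlorine or a methyl group on that aromatic carbon would match bromine remains open. Also open, on these data alone, is whether bromine gives a step of similar size alongside 4-nitrophenyl on the sulfonyl sulfur.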